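The source may hold more compounds than are shown below. What is called first, only, known or untested is meant among the compounds shown, and "the series" means these compounds.

Of the compounds shown here, three sharing one core have so far been tested in an ADME assay on MRC5 cells (Homo sapiens) for cytotoxicity, read by MTT assay; a lower number here means that less compound is tolerated, a higher number that more compound is tolerated. Compound 1, `O=c1[nH]c(=O)n([C@@H]2O[C@H](CO)[C@@H](O)[C@H]2O)cc1C#CC1CCCCC1`, gives 36800 nM. Compound 2, `O=c1[nH]c(=O)n([C@@H]2O[C@H](CO)[C@@H](O)[C@H]2O)cc1C#CC(O)c1ccccc1`, gives 900 nM. Compound 3, `O=c1[nH]c(=O)n([C@@H]2O[C@H](CO)[C@@H](O)[C@H]2O)cc1C#Cc1ccccc1`, gives 1200 nM. Compound 3 thus stands second highest of the three numbers: it sits within the scatter of compound 2, with a 1.3-fold higher number from compound 2 to compound 3 (0.12 log units; within the scatter), and well apart from compound 1, with a 31-fold lower number from compound 1 to compound 3 (1.49 log units; beyond the scatter).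

The step now followed leads to compound 4, `CCCCCCC#Cc1cn([C@@H]2O[C@H](CO)[C@@H](O)[C@H]2O)c(=O)[nH]c1=O`, which has not yet been measured. The change is hexyl in place of phenyl on a triple-bonded carbon. For the measured compounds named here, one measured step bears on it: a 31-fold lower number from compound 1 to compound 3 (1.49 log units; beyond the scatter), where cyclohexyl gave way to phenyl on the same triple-bonded carbon. The move to compound 4 runs the other way, replacing phenyl with a group that has no ring, so on that single precedent a rise in the number is expected in this assay. Hexyl is a chain rather than a ring, however, so the size of the rise is uncertain and may be smaller than the earlier step. Compound 4 is therefore expected to give about 15000 nM, within a range from 4000 nM to 60000 nM, an estimated step of a 13-fold higher number from compound 3 to compound 4 (1.10 log units; beyond the scatter).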

Compound 4, half-maximal cytotoxic concentration: 15700 nM
Estimate against measurement, compound 4: 1.0-fold (0.02 log units) below, and the stated range covers the measured number.
By their numbers in this assay, from the lowest: compounds 2 and 3 (each within the scatter of the next); then compound 4; then compound 1.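

In this assay, hexyl in place of phenyl on the triple-bonded carbon gives (a 13-fold higher number from compound 3 to compound 4 (1.12 log units; beyond the scatter)), and hexyl in place of hydroxy(phenyl)methyl gives a step of similar scale (a 17-fold higher number from compound 2 to compound 4 (1.24 log units; beyond the scatter)); since hexyl and phenyl hold the same count of carbon atoms, that count alone does not set the number at this position. Compound 4 also shows that a ring is not needed for a high number, although the step from a ring to a chain without an aromatic ring is much smaller (a 2.3-fold lower number from compound 1 to compound 4 (0.37 log units; beyond the scatter)) and still lies beyond the scatter. Among these four compounds, the two carrying a phenyl group have the low numbers and the two without one have the high numbers, with none going against this, but nothing here explains the split.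

The compounds shown leave open whether a shorter or longer chain, or a hexyl chain ending in an amine or a carboxylic acid, would keep the high number. They also leave open whether a non-aromatic ring of another size, or a phenyl ring carrying fluorine or methoxy, would follow the same split.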